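Swapping Fluoro for Methoxy: From Compound 2 to Compound 3

The source may hold more compounds than are shown below. What is called first, only, known or untested is meant among the compounds shown, and "the series" means these compounds.

Going by the values given here, compound 2 `COc1cc(C(=O)/C=C/c2c(-c3ccc(F)cc3)nc3ncccn23)cc(OC)c1OC` shows the lowest of the two numbers measured so far in a functional assay on BT-549 cells (Homo sapiens) for inhibition, read by sulforhodamine B assay, with a stated time of 48 h; on this read-out lower numbers stand for stronger inhibition of growth and higher numbers for weaker inhibition of growth; compound 2 gives 1800 nM. Compound 1 `COc1ccc(-c2nc3ccccn3c2/C=C/C(=O)c2cc(OC)c(OC)c(OC)c2)cc1` gives 3270 nM in this assay, a value within the scatter of that of compound 2, so no order between the two can be claimed. Compound 3 `COc1ccc(-c2nc3ncccn3c2/C=C/C(=O)c2cc(OC)c(OC)c(OC)c2)cc1` has not yet been measured; it differs from compound 2 by methoxy in place of fluoro on an aromatic carbon. Among the compounds with values here, no measured pair isolates this change. In this assay the step is expected to be a small one, estimated as a 1.4-fold higher number from compound 2 to compound 3 (0.14 log units; within the scatter). Compound 3 is therefore estimated at 2500 nM, between 1000 nM and 6000 nM.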

Compound 3, concentration for 50% growth inhibition: 1450 nM
Estimate against measurement, compound 3: 1.7-fold (0.24 log units) above, within the range that was stated.
By their numbers in this assay, from the lowest: compounds 3, 2 and 1 (each within the scatter of the next, the first and the last beyond it).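

In this assay, the swap of 4-fluorophenyl to 4-methoxyphenyl now stands as a measured pair, and a 1.2-fold lower number from compound 2 to compound 3 (0.09 log units; within the scatter) is the whole of its effect. On this aromatic carbon, para to a large group, methoxy and fluoro therefore cannot be told apart in growth inhibition. Nothing available bears on why the two groups read alike. The compounds shown leave open whether an amine, a carboxylic acid or a longer alkoxy chain at this position would move the number beyond the scatter. They also leave open whether this swap would read the same on the core of compound 1.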